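Vero cytotoxicity notes: acyl change on compound 1

The source may report more compounds than this note shows. Statements on the series, on what has been measured and on what is new or still open speak of the compounds shown alone.

Compound 1, `CCCCCC(=O)Nc1cc2nc(C3CCCCC3)[nH]c2cc1N1CCCC1`, has been tested in an ADME assay on Vero cells (Chlorocebus sabaeus) for cytotoxicity, read by resazurin assay, with a stated time of 3 days; a higher number here means a weaker inhibitor, a lower number a stronger inhibitor. In this assay compound 1 gives > 100 ug/mL, which is a limit of the assay and not a number. Compound 2, `CCCCCC(=O)Nc1cc2nc(C3CCCCC3)[nH]c2cc1N(C)C`, is the only other measured point. In this assay compound 2 gives > 100 ug/mL, again a limit rather than a number. The step from compound 1 to compound 2 in this assay is a step that the two limits leave unreadable from compound 1 to compound 2, so no size can be read from it. Both values sit at the limit of > 100 ug/mL in this assay, at which 2 of the 2 values shown sit. Compound 3, `O=C(Nc1cc2nc(C3CCCCC3)[nH]c2cc1N1CCCC1)c1ccccc1`, is not yet measured. It differs from compound 1 as follows: phenyl in place of pentyl on a carbonyl carbon. Going by the values given here, no measured step touches the carbonyl carbon, so there is no guide to the size of this change. With compound 1 sitting at the limit of > 100 ug/mL in this assay, at which 2 of the 2 values shown sit, the step of a number no higher from compound 1 to compound 3 (the limit leaves the size open) is expected to be none beyond the scatter. The estimate for compound 3 in this assay is 100 ug/mL, with a range from 40 ug/mL to 200 ug/mL.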

Compound 3, half-maximal inhibitory concentration: > 100 ug/mL
Compound 3: a limit, no number; the forecaster's own chance of this, stated with the estimate: 75%; the middle value sits exactly at the limit.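

Going by these compounds alone, compound 1 and compound 3 both stand at a limit in this assay and not at a number, so no step between them can be read: (the limit of > 100 ug/mL in this assay, at which 3 of the 3 values shown sit). The compounds shown leave open how cytotoxic any of them is, and what phenyl in place of pentyl does to that value.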